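The source may report more compounds than this note shows. Statements on the series, on what has been measured and on what is new or still open speak of the compounds shown alone.

Compound 2, `CC1=CC[C@H](C(C)C)c2cc(C)c(OC(=O)c3ccccc3)cc21`, gives 25.8% in a functional assay on U-251 cells (Homo sapiens) for antiproliferative activity, read by sulforhodamine B assay, with a stated time of 48 h, tested at 50 uM (on this read-out lower numbers stand for less inhibition and higher numbers for more inhibition at the one concentration tested (going by the name of the read-out)), and so stands lowest of the two numbers measured. For the measured compounds named here, its only neighbour is compound 1, `CC1=CC[C@H](C(C)C)c2cc(C)c(OC(=O)c3ccc(C)cc3)cc21`, which in this assay gives 67.7%; the step of a number 41.9 percentage points lower from compound 1 to compound 2 (beyond the scatter) is the one measured step that bears on what follows, and it was large and beyond the scatter.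

Compound 3, `CC1=CC[C@H](C(C)C)c2cc(C)c(OC(=O)c3ccc(C(F)(F)F)cc3)cc21`, differs from compound 2 by trifluoromethyl in place of hydrogen on an aromatic carbon. The place of the change is the same aromatic carbon, para to a large group, at which compound 1 carries its methyl and compound 2 carries hydrogen. Since the loss of the methyl there cost compound 2 a large share of its inhibition, putting a group back at that place is expected to move this assay upward again, though how far a trifluoromethyl tracks a methyl cannot be read from a single step. Compound 3 is therefore expected to rise by a number 24.2 percentage points higher from compound 2 to compound 3 (beyond the scatter) in this assay, to about 50%, with a range from 25% to 75%.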

Compound 3, a percentage reported as inhibition, at one concentration (the size of the read-out at that concentration, not a potency): 14.7%
The estimate for compound 3 lay 35.3 percentage points above the measured number; the measured number lies below the stated range.
By their numbers in this assay, from the lowest: compound 3; then compound 2; then compound 1.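

In this assay, this aromatic carbon, para to a large group, does not simply reward any group placed on it. Trifluoromethyl in place of hydrogen gives a number 11.1 percentage points lower from compound 2 to compound 3 (beyond the scatter), so the two groups placed here part in direction: methyl stands above hydrogen, while trifluoromethyl stands below it. Trifluoromethyl in place of methyl gives a number 53 percentage points lower from compound 1 to compound 3 (beyond the scatter), which shows that the higher inhibition of compound 1 goes with methyl in particular and not with the mere presence of a group at this place, and nothing available here explains why these two groups differ so widely.

With only hydrogen, methyl and trifluoromethyl to compare, the compounds shown leave open how other groups at this carbon would rank, such as an ethyl group, a methoxy group, a chlorine atom or an amine. They also leave open whether a group larger than methyl but made only of carbon and hydrogen, such as a longer chain, would keep the inhibition of compound 1 or lose it as compound 3 does.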